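Chalcone series on colon carcinoma cells: trimethoxyphenyl swap

The source may report more compounds than this note shows. Statements on the series, on what has been measured and on what is new or still open speak of the compounds shown alone.

Measured so far:
compound 1 `O=C(/C=C/c1cccc(O)c1)c1cccc(-n2cc(-c3ccccc3)[nH]c2=O)c1` gives 3330 nM in a functional assay on HT-29 cells (Homo sapiens) for inhibition; on this read-out lower numbers stand for stronger inhibition of growth and higher numbers for weaker inhibition of growth;
compound 2 `COc1cc(/C=C/C(=O)c2cccc(-n3cc(-c4ccccc4)[nH]c3=O)c2)cc(OC)c1OC` gives 660 nM in this assay.

Among the compounds with values here, compound 2 stands lowest of the two numbers; its only neighbour, compound 1, sits well above it, a gap beyond the usual scatter. Compound 3 `COc1cc(/C=C/C(=O)c2cccc(-n3cc(-c4cc(OC)c(OC)c(OC)c4)[nH]c3=O)c2)cc(OC)c1OC` is not yet measured in this assay. It differs from compound 2 in one place: 3,4,5-trimethoxyphenyl in place of phenyl on an aromatic carbon. Within the data shown here, this change sits on the shared core rather than on the chalcone end where the two measured compounds differ, so the data give no direct precedent for it. A step in either direction is possible; a mild loss or no change beyond the scatter is expected as the most likely outcome. For compound 3 the expected step is a 1.5-fold higher number from compound 2 to compound 3 (0.18 log units; within the scatter). Compound 3 is therefore estimated at 1000 nM, with a range from 300 nM to 3300 nM.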

Compound 3, concentration for 50% growth inhibition: 1700 nM
Compound 3: the middle estimate sits 1.7-fold (0.23 log units) below what was measured; measured number inside the range.
By their numbers in this assay, from the lowest: compound 2; then compounds 3 and 1 (each within the scatter of the next).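

Placing 3,4,5-trimethoxyphenyl in place of phenyl on this aromatic carbon of the shared core gives the first reading at this position: in this assay, growth inhibition weakens modestly (a 2.6-fold higher number from compound 2 to compound 3 (0.41 log units; beyond the scatter)). The position therefore tolerates the larger group with some loss, and compound 3 still gives 1700 nM with the trimethoxyphenyl group on both ends of the molecule. Nothing available bears on the reason for this step.

Still open, on these data alone, is whether the loss depends on all three methoxy groups or would also follow from a single methoxy, a fluorine or an amine on this phenyl ring. Also open, as far as these compounds go, is whether the same swap would produce a step of similar size with the chalcone end of compound 1.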